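Adding a Methoxy Group to a Diallylamino Cyanoacrylic Acid

The source may hold more compounds than are shown below. What is called first, only, known or untested is meant among the compounds shown, and "the series" means these compounds.

The measured compounds:
compound 1, `C=CCN(CC=C)c1ccc(/C=C(\C#N)C(=O)O)cc1`: 110 nM
compound 2, `C#CCN(CC#C)c1ccc(/C=C(\C#N)C(=O)O)cc1`: 400 nM

In an assay on RBE4 cells for inhibition of Monocarboxylate transporter 1 (Rattus norvegicus), with a stated time of 15 min (a higher number here means a weaker inhibitor, a lower number a stronger inhibitor), compound 1 gives 110 nM, the lower of the two numbers shown. Compound 2 gives 400 nM, a higher number, and the gap between them lies beyond the usual scatter of repeated measurements, so compound 1 is the stronger inhibitor of the pair.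

Compound 3, `C=CCN(CC=C)c1ccc(/C=C(\C#N)C(=O)O)c(OC)c1`, differs from compound 1 by a single change: methoxy in place of hydrogen on an aromatic carbon. Going by the values given here, no measured pair shows this kind of change, so there is no direct guide to its effect. With the shared core and the diallylamino group kept intact, the step from compound 1 to compound 3 is expected to be small, no more than the scatter, as a 1.1-fold higher number from compound 1 to compound 3 (0.04 log units; within the scatter) expresses. Compound 3 is therefore estimated at 120 nM, with a plausible range from 40 nM to 350 nM.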

Compound 3, half-maximal inhibitory concentration: 29 nM
Compound 3: the middle estimate sits 4.1-fold (0.62 log units) above what was measured, outside the stated range (below it).
By their numbers in this assay, from the lowest: compound 3; then compound 1; then compound 2.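

In this assay, a methoxy on the aromatic carbon ortho to the 2-carboxy-2-cyanoethenyl group and meta to the diallylamino group gives a 3.8-fold lower number from compound 1 to compound 3 (0.58 log units; beyond the scatter). The earlier pair differed only in the chains on the nitrogen and said nothing about the ring, whereas this step shows that a change at this ring carbon alone, with the diallylamino group untouched, yields a stronger inhibitor. No measurement shown here explains the stronger inhibition.

As far as these compounds go, it remains open whether the gain belongs to methoxy itself or would also appear with a hydroxyl, a fluorine or an ethoxy group on the same carbon. Also open, from the compounds shown here alone, is whether methoxy would give a similar step on another ring carbon or alongside the nitrogen chains of compound 2.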